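The source may report more compounds than this note shows. Statements on the series, on what has been measured and on what is new or still open speak of the compounds shown alone.

In a functional assay on A2780 cells (Homo sapiens) for antiproliferative activity, read by MTT assay, with a stated time of 72 h (on this read-out higher numbers stand for weaker inhibition and lower numbers for stronger inhibition), compound 2 `O=C(c1cc2ccccc2o1)N1N=C(c2ccc(F)cc2)CC1c1ccccc1` gives 11.8 ug/mL. Compound 3 `O=C(c1cc2ccccc2o1)N1N=C(c2ccc(F)cc2)CC1c1ccc(Cl)cc1` is known only as a limit, > 50 ug/mL, so its exact place on the scale is open. Compound 4 `O=C(c1cc2ccccc2o1)N1N=C(c2ccc(F)cc2)CC1c1ccc([N+](=O)[O-])cc1` puts nitro in place of the chloro of compound 3: nitro in place of chloro on an aromatic carbon. Within the data shown here, the one measured step at this aromatic carbon is an at least 4.2-fold higher number from compound 2 to compound 3 (0.62 log units; beyond the scatter), beyond the scatter, with chloro in place of hydrogen. Compound 1 `O=C(c1cc2ccccc2o1)N1N=C(c2ccc(Cl)cc2)CC1c1ccc([N+](=O)[O-])cc1`, which differs elsewhere but also carries the 4-nitrophenyl group, gives 34.1 ug/mL, a number rather than a limit. A modest move toward stronger inhibition is therefore expected, with an estimated at least 1.6-fold lower number from compound 3 to compound 4 (0.22 log units; that floor lies within the scatter). Compound 4 is estimated at 30 ug/mL, with an expected range of 13 ug/mL to 50 ug/mL.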

Compound 4, half-maximal inhibitory concentration: > 50 ug/mL
Compound 4: a limit, no number; the forecaster's own chance of this, stated with the estimate: 30%; middle value at least 1.6-fold (0.22 log units) from the limit.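

In this assay, nitro in place of hydrogen on this aromatic carbon gives an at least 4.2-fold higher number from compound 2 to compound 4 (0.62 log units; beyond the scatter), so compound 4 joins compound 3 in showing that a group here can weaken inhibition. Fluoro in place of chloro at the other end of the core gives an at least 1.4-fold higher number from compound 1 to compound 4 (0.16 log units; that floor lies within the scatter), so that change is not shown to matter beyond the scatter. Nitro and chloro cannot be ranked, since the step between their two compounds cannot be read: the limit of > 50 ug/mL in this assay, at which 2 of the 4 values shown sit.

From the compounds shown here alone, whether an amine or a methoxy group on this carbon would hold the level of compound 2 remains open. So does the true level of both compounds known only as limits.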